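Oxazole-ketone series: chloro oxazole following the methyl analogue

The source may hold more compounds than are shown below. What is called first, only, known or untested is meant among the compounds shown, and "the series" means these compounds.

Compound 1 `O=C(CCCCCCc1ccccc1)c1nc(C(=O)C(F)(F)F)co1` gives 123 nM in an assay on HEK-293T cells for inhibition of diacylglycerol lipase-alpha (Homo sapiens), read by colorimetric assay; a higher number here means a weaker inhibitor, a lower number a stronger inhibitor. Compound 2 `Cc1coc(C(=O)CCCCCCc2ccccc2)n1` reaches only > 10000 nM in this assay, which is a limit of the assay rather than a number (the limit of > 10000 nM in this assay, at which 1 of the 2 values shown sits). The step of an at least 81-fold higher number from compound 1 to compound 2 (1.91 log units; beyond the scatter) is the only measured one. Compound 3 `O=C(CCCCCCc1ccccc1)c1ncc(Cl)o1` differs from compound 2 by 5-chloro-1,3-oxazol-2-yl in place of 4-methyl-1,3-oxazol-2-yl on a carbonyl carbon, keeping the alkyl chain and the core of compound 2 but carrying no (trifluoromethyl)carbonyl. As that group's loss drove the large step in this assay, compound 3 is expected to stay weak, with the step of an at least 1.6-fold lower number from compound 2 to compound 3 (0.22 log units; that floor lies within the scatter) estimated as small. The estimate for compound 3 in this assay is 6000 nM, between 1500 nM and 30000 nM.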

Compound 3, half-maximal inhibitory concentration: > 10000 nM
Compound 3 ended at the assay's limit; the forecaster's own chance of this, stated with the estimate: 45%; middle value at least 1.6-fold (0.22 log units) from the limit.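

No step can be read from compound 2 to compound 3 in this assay, as both values are limits of the assay: the limit of > 10000 nM in this assay, at which 2 of the 3 values shown sit.

Left open is how 5-chloro-1,3-oxazol-2-yl and 4-methyl-1,3-oxazol-2-yl compare in this assay once the number falls inside the assay's range.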